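This account rests on a few compounds, and the source may have more. Where it says the series, first, only, none or still open, it means among the compounds named here.

Compound 1 `COc1cc(C(=O)NC2CCN(C)CC2)ccc1Nc1ncc2c(n1)N(C1CCCC1)[C@H](C)C(=O)N2C` and compound 2 `COc1cc(C(=O)NC2CCN(C)CC2)ccc1Nc1ncc2c(n1)N(C1CCCC1)[C@@H](C)C(=O)N2C` share one core and differ only in the configuration drawn at a stereocentre on a saturated ring carbon. In an assay on isolated protein for inhibition of serine/threonine-protein kinase PLK1 (Homo sapiens), read by Z'-LYTE (on this read-out lower numbers stand for stronger inhibition and higher numbers for weaker inhibition), compound 1 gives 1.1 nM, the lowest of the two numbers recorded, and compound 2 gives 8.7 nM. Going by the values given here, the one measured step, a 7.9-fold higher number from compound 1 to compound 2 (0.90 log units; beyond the scatter), rests on the fact that compounds 1 and 2 differ only in the configuration as drawn alone. Compound 3 `COc1cc(C(=O)NC2CCCCC2)ccc1Nc1ncc2c(n1)N(C1CCCC1)[C@H](C)C(=O)N2C` keeps the configuration of compound 1 and alters a different part of the molecule: cyclohexyl in place of 1-methylpiperidin-4-yl on an amide-type nitrogen. Among the compounds with values here, no measured step touches this amide substituent, since the only step recorded in this assay concerns the stereocentre; it gives no guide to the size or direction of the change from compound 1 to compound 3. With the rest of the molecule untouched and a six-membered non-aromatic ring kept in place, the step is expected to be small, a 1.8-fold higher number from compound 1 to compound 3 (0.26 log units; within the scatter), with no direction claimed beyond the scatter. For compound 3 in this assay an estimate of 2 nM is therefore expected, in a range from 0.5 nM to 8 nM.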

Compound 3, half-maximal inhibitory concentration: 160 nM
Estimate against measurement, compound 3: 80-fold (1.90 log units) below, outside the stated range (above it).
By their numbers in this assay, from the lowest: compound 1; then compound 2; then compound 3.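

In this assay the amide substituent turns out to be the more sensitive of the two places varied: cyclohexyl in place of 1-methylpiperidin-4-yl on the amide-type nitrogen gives a 150-fold higher number from compound 1 to compound 3 (2.16 log units; beyond the scatter), well beyond a 7.9-fold higher number from compound 1 to compound 2 (0.90 log units; beyond the scatter) seen at the stereocentre. Keeping a six-membered non-aromatic ring in place therefore does not by itself hold the number, and the two groups differ in that the entering ring is of carbon only, while the leaving ring carries one hetero atom, a nitrogen counted as a hydrogen-bond acceptor, and a methyl group on it. Going by these compounds alone, what is known about these compounds does not bear on why this exchange moves the number so far.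

The compounds shown leave open whether the ring nitrogen or its methyl group carries the difference: piperidin-4-yl, tetrahydropyran-4-yl or an open-chain 2-(dimethylamino)ethyl group on the amide-type nitrogen would separate these readings. They also leave open whether the cyclohexyl exchange would give a step of similar size in the configuration of compound 2.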